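The source may hold more compounds than are shown below. What is called first, only, known or untested is meant among the compounds shown, and "the series" means these compounds.

Of the compounds shown here, three with a shared amide-linked core have been measured in a functional assay on HCT-116 cells (Homo sapiens) for antiproliferative activity, read by MTT assay; a higher number here means a weaker inhibitor, a lower number a stronger inhibitor. Compound 1 `Nc1ccccc1NC(=O)/C=C/c1ccc(NCc2ccncc2)nc1` gives 7000 nM in this assay, and compound 2 `COc1cc(CNc2ccc(/C=C/C(=O)Nc3ccccc3N)cn2)cc(OC)c1OC` gives 2000 nM. Compound 3 `COc1ccc(CNc2ccc(/C=C/C(=O)Nc3ccccc3N)cc2)cc1` gives 37000 nM, the highest of the three numbers and the weakest inhibitor of the set, with each gap to the other two beyond the usual scatter. Compound 4 `Nc1ccccc1NC(=O)/C=C/c1ccc(NCc2ccncc2)cc1` has not yet been measured; it differs from compound 3 in one place: pyridin-4-yl in place of 4-methoxyphenyl on a saturated chain carbon bound to a nitrogen on an aromatic ring. Among the compounds with values here, no measured pair isolates this same change, so the expectation rests on the set as a whole. The step from compound 3 to compound 4 is expected to be modest, a 1.9-fold lower number from compound 3 to compound 4 (0.27 log units; within the scatter), toward a somewhat lower number. Compound 4 is therefore estimated at 20000 nM, with a range from 6000 nM to 60000 nM.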

Compound 4, half-maximal inhibitory concentration: 2000 nM
Estimate against measurement, compound 4: 10-fold (1.00 log units) above; measured number below the stated range.
By their numbers in this assay, from the lowest: compounds 2 and 4 (each within the scatter of the next); then compound 1; then compound 3.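

In this assay, pyridin-4-yl in place of 4-methoxyphenyl on a saturated chain carbon bound to a nitrogen on an aromatic ring gives a 19-fold lower number from compound 3 to compound 4 (1.27 log units; beyond the scatter) as a large step. Within the data shown here, this is the first pair differing in one place, and it shows that the number responds strongly to the group held at this position. No other measurement here explains the size of this step.

Going by these compounds, the change removes the methoxy group and adds a ring nitrogen together, so the separate contribution of each remains open. A plain phenyl group at this position could separate them, while pyridin-3-yl could test whether the location of the ring nitrogen matters.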